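The source may hold more compounds than are shown below. What is called first, only, known or untested is meant among the compounds shown, and "the series" means these compounds.

In a functional assay on A549 cells (Homo sapiens) for antiproliferative activity, read by MTT assay, with a stated time of 72 h (on this read-out higher numbers stand for weaker inhibition and lower numbers for stronger inhibition), compound 1 `CCCCCCCCCCCNC[C@@H]1OC[C@H](N)[C@@H]1O` gives 11100 nM and its stereoisomer, compound 2 `CCCCCCCCCCCNC[C@@H]1OC[C@H](N)[C@H]1O`, gives 9650 nM. Among the compounds with values here, these two values lie within the scatter of each other, so compound 1 has no clear standing on the numbers so far. Within the data shown here, the only measured step is a 1.2-fold lower number from compound 1 to compound 2 (0.06 log units; within the scatter). It reflects the fact that compounds 1 and 2 differ only in the configuration as drawn and leaves the chain untouched, so it gives no direct size for a change in chain length. Among the measured compounds shown here, it shows only that this one change in configuration made no difference beyond the scatter in this assay.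

Compound 3 `CCCCCCCCCCCCCCNC[C@@H]1OC[C@H](N)[C@@H]1O` keeps the core and configuration of compound 1 and differs by propyl in place of hydrogen on a saturated chain carbon, ten or more bonds along the chain from an amine nitrogen. The same difference also reads as methyl to butyl. For the measured compounds named here, no measured pair varies the chain, so both the size and the direction remain tentative. A modest move to a lower number is expected, with the estimated step being a 1.7-fold lower number from compound 1 to compound 3 (0.23 log units; within the scatter). The range is kept wide on either side of that expectation, and a result unchanged from compound 1 would fall inside it. For compound 3 the estimated value is 6500 nM, with an expected range of 2500 nM to 15000 nM.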

Compound 3, half-maximal inhibitory concentration: 2850 nM
Compound 3: the middle estimate sits 2.3-fold (0.36 log units) above what was measured; measured number inside the range.
By their numbers in this assay, from the lowest: compound 3; then compounds 2 and 1 (each within the scatter of the next).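

In this assay, within the data shown here, propyl in place of hydrogen on a saturated chain carbon, ten or more bonds along the chain from an amine nitrogen, gives a 3.9-fold lower number from compound 1 to compound 3 (0.59 log units; beyond the scatter), which makes this the first step to lie beyond the scatter. Among these compounds, the only earlier step, a 1.2-fold lower number from compound 1 to compound 2 (0.06 log units; within the scatter), concerned configuration and left the chain unchanged, so the series now shows that this outer part of the chain is a place where the number responds, and that the added carbons move it towards stronger inhibition. The step gives a direction and a size for this single change, but no measured property shown here bears on why the number moves.

On these data alone, a single step cannot define a trend with chain length, so it remains open whether a still longer chain would lower the number further or reverse the move, and whether a chain carrying a hydroxyl group or a phenyl ring would keep the gain. As far as these compounds go, it also remains open whether the configuration change from compound 1 to compound 2 would stay within the scatter on the longer chain of compound 3.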